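Swapping Phenyl for Quinolinyl on the Sulfonyl Sulfur

The source may report more compounds than this note shows. Statements on the series, on what has been measured and on what is new or still open speak of the compounds shown alone.

Of the compounds shown here, three built on a shared core have been measured in a functional assay on A2780 cells (Homo sapiens) for antiproliferative activity, read by sulforhodamine B assay, with a stated time of 72 h; on this read-out lower numbers stand for stronger inhibition and higher numbers for weaker inhibition. Compound 1 `N#C/N=C(\NCc1ccc(S(=O)(=O)c2ccccc2)cc1)Nc1cccnc1` gives 30 nM. Compound 2 `N#C/N=C(\NCc1ccc(S(=O)(=O)c2ccccc2)cc1)Nc1ccncc1`, which carries pyridin-4-yl in place of pyridin-3-yl, gives 9.7 nM; the step of a 3.1-fold lower number from compound 1 to compound 2 (0.49 log units; beyond the scatter) is modest but beyond the scatter. Compound 3 `N#C/N=C(\NCc1ccc(S(=O)(=O)N2CC3CCC(C2)O3)cc1)Nc1cccnc1` gives 175 nM, and the step of a 5.8-fold higher number from compound 1 to compound 3 (0.77 log units; beyond the scatter) shows that replacing the phenyl on the sulfonyl sulfur with a non-aromatic bicyclic group weakens inhibition. Compound 2 thus stands lowest of the three numbers, with compound 1 nearest and compound 3 furthest.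

Compound 4 `N#C/N=C(\NCc1ccc(S(=O)(=O)c2cccc3cccnc23)cc1)Nc1ccncc1` has not yet been measured. It differs from compound 2 by quinolin-8-yl in place of phenyl on a sulfonyl sulfur. Within the data shown here, no measured step changes the phenyl into another aromatic group, so the only step touching this position is a 5.8-fold higher number from compound 1 to compound 3 (0.77 log units; beyond the scatter), which went to a non-aromatic ring and weakened inhibition modestly. The change in compound 4 keeps an aromatic ring and adds a second, so the expected step of a 1.5-fold higher number from compound 2 to compound 4 (0.19 log units; within the scatter) is small, possibly toward weaker inhibition, and may not exceed the scatter. Compound 4 is therefore estimated at 15 nM, within a range from 4 nM to 60 nM.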

Compound 4, half-maximal inhibitory concentration: 14 nM
Beside the measured number, compound 4's estimate is 1.1-fold (0.03 log units) above it, within the range that was stated.
By their numbers in this assay, from the lowest: compounds 2 and 4 (each within the scatter of the next); then compound 1; then compound 3.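

In this assay, the step of a 1.4-fold higher number from compound 2 to compound 4 (0.16 log units; within the scatter) shows that the sulfonyl sulfur of this series can carry quinolin-8-yl in place of phenyl without a change that can be told from the scatter, even though the entering group has a second aromatic ring and a hydrogen-bond acceptor. Among these compounds, until now, the only step at this place was a 5.8-fold higher number from compound 1 to compound 3 (0.77 log units; beyond the scatter) and it led to a non-aromatic group, so the new pair gives the first view of a different aromatic group here, in the pyridin-4-yl series rather than the pyridin-3-yl series of that earlier step. Nothing given here offers a reason for either result.

The compounds shown leave open whether the extra ring or its nitrogen has any effect of its own, a question that a naphthyl group, with two aromatic rings of carbon only, could help to separate. They also leave open how a small chain such as methyl or a simple amine would fare on the sulfonyl sulfur, and whether quinolin-8-yl behaves the same way with pyridin-3-yl on the shared core.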